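The compounds below may be only part of what the source reports. "The series", "measured", "known", "first", "only" and "open" are said of these compounds alone.

In a functional assay on LoVo cells (Homo sapiens) for cytotoxicity, read by colorimetric assay and MTT assay (a higher number here means a weaker inhibitor, a lower number a stronger inhibitor), compound 1 `COc1cc(OC)c2cc(-c3ccccc3)c(O)nc2c1` gives 10000 nM, and compound 2 `CCN(CC)C(=O)Cn1c(=O)c(-c2ccc(OC)cc2)cc2c(OC)cc(OC)cc21` stands level with it at 10000 nM. Compound 3 `COc1ccc(-c2cc3c(OC)cc(OC)cc3n(CCCC#N)c2=O)cc1` has not yet been measured. It differs from compound 2 in one place, with 2-cyanoethyl in place of diethylcarbamoyl on a saturated chain carbon bound to an aromatic nitrogen. Within the data shown here, no measured pair yet shows what a change of this kind does, so no step beyond the scatter is expected in this assay, in either direction. The estimated change is small, a 1.3-fold lower number from compound 2 to compound 3 (0.10 log units; within the scatter). Compound 3 is expected to give about 8000 nM, with an estimated range of 2500 nM to 15000 nM.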

Compound 3, half-maximal inhibitory concentration: 10000 nM
For compound 3 the middle estimate is 1.3-fold (0.10 log units) below the measured one; low and high end bracket the measured number.
By their numbers in this assay, from the lowest: compounds 1, 2 and 3 (each within the scatter of the next).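

Among these compounds, the step of no change at the digits printed from compound 2 to compound 3 (within the scatter) in this assay is the first measured pair at this position, on a saturated chain carbon bound to an aromatic nitrogen. It shows that 2-cyanoethyl can take the place of diethylcarbamoyl there without any change in the number at the digits printed. Nothing measured here offers an explanation for this result. Still open, on these data alone, is whether an amine, a carboxylic acid or a longer chain in this place would give a different number on the same core.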